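Purine series: trimming the arylmethyl sulfanyl group

This account rests on a few compounds, and the source may have more. Where it says the series, first, only, none or still open, it means among the compounds named here.

Of the compounds shown here, two have numbers so far. Compound 1 `Nc1nc(SCc2ccc(Br)cc2)c2ncn([C@@H]3O[C@H](CO)[C@@H](O)[C@H]3O)c2n1` is the lower of the two: in an assay on isolated protein for binding affinity to Equilibrative nucleoside transporter 1 (Homo sapiens) (on this read-out higher numbers stand for weaker inhibition and lower numbers for stronger inhibition), compound 1 gives 813 nM. Compound 2 `CCCSc1nc(N)nc2c1ncn2CC(C)C`, which carries a propylsulfanyl group and an isobutyl chain in place of the sugar, gives in this assay 63100 nM, a gap that lies well beyond the scatter. Among the compounds with values here, compound 2 differs from compound 1 in more than one place, so no single step between them can be read.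

Compound 3 `CSc1nc(N)nc2c1ncn2[C@@H]1O[C@H](CO)[C@@H](O)[C@H]1O` keeps the sugar of compound 1 and differs from it by the change (hydrogen in place of 4-bromophenyl on a saturated chain carbon bound to a sulfur). Within the data shown here, no measured pair shows this change alone, so its size must be guessed. The expectation is a step from compound 1 to compound 3 of a 25-fold higher number from compound 1 to compound 3 (1.39 log units; beyond the scatter), toward a weaker number in this assay, and of a size clearly beyond the scatter. For compound 3 the estimate in this assay is 20000 nM, with a range from 3000 nM to 120000 nM.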

Compound 3, half-maximal inhibitory concentration: 204000 nM
Beside the measured number, compound 3's estimate is 10-fold (1.01 log units) below it, outside the stated range (above it).
By their numbers in this assay, from the lowest: compound 1; then compound 2; then compound 3.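

Within the data shown here, with the sugar and the rest of the core held fixed, going from (4-bromobenzyl)sulfanyl to methylsulfanyl gives in this assay a large step, a 250-fold higher number from compound 1 to compound 3 (2.40 log units; beyond the scatter), and this is the first single change that can be read. The position on the saturated chain carbon bound to a sulfur is therefore far from indifferent: in this pair, the stronger number goes with the 4-bromophenyl, and replacing that group with hydrogen is enough on its own to produce the whole step. No measurement shown here bears on the reason for a step of this size.

Steps involving compound 2 cannot be read, as it differs from both compound 1 and compound 3 in more than one place, so the propylsulfanyl group gives no clean intermediate point on this chain. Still open, on these data alone, is how much of the step belongs to the bromine and how much to the aromatic ring, a question that a plain benzyl group or a phenethyl chain on the sulfur, each on the same sugar-bearing core, would help to separate.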